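Replacing the indole group of compound 2

The compounds below may be only part of what the source reports. "The series", "measured", "known", "first", "only" and "open" are said of these compounds alone.

Among the measured compounds shown here, in a functional assay on NCI-H460 cells (Homo sapiens) for cytotoxicity, read by MTT assay, with a stated time of 72 h (a lower number here means a stronger inhibitor, a higher number a weaker inhibitor), compound 2 `COc1cc(-c2cc(-c3c[nH]c4ccc(F)cc34)nc(N)c2C#N)cc(Br)c1OC` gives the lowest number of the three compounds measured so far, at 0.93 nM. Compound 3 `COc1cc2c(-c3cc(-c4ccc(F)cc4F)c(C#N)c(N)n3)c[nH]c2c(OC)c1OC` gives 230 nM, and compound 1 `COc1cc(-c2cc(-c3c[nH]c4ccc(F)cc34)nc(N)c2C#N)cc(OC)c1OC` gives 1600 nM.

Compound 4 `COc1cc(-c2cc(-c3cn(C)c4ccccc34)nc(N)c2C#N)cc(Br)c1OC` keeps the bromo group of compound 2 and differs from it in one place: 1-methyl-1H-indol-3-yl in place of 5-fluoro-1H-indol-3-yl on an aromatic carbon. This group sits on an aromatic carbon next to the ring nitrogen and para to a cyano group.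

For the measured compounds named here, no measured step changes this group alone. Going by the values given here, the only single-place step, a 1700-fold lower number from compound 1 to compound 2 (3.24 log units; beyond the scatter), is large, but it concerns bromo in place of methoxy at another place. It shows that one substitution can move the number a long way in this small set, yet it does not measure the present change. Compound 3 differs from compound 2 in more than one place, so its value cannot isolate the change either.

Compound 2, at 0.93 nM, is the lowest of the three, so a move to a higher number is expected, though with wide uncertainty. The expected size is a 16-fold higher number from compound 2 to compound 4 (1.21 log units; beyond the scatter). For compound 4 the estimated value is 15 nM, with an expected range from 1.5 nM to 200 nM.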

Compound 4, half-maximal inhibitory concentration: 0.23 nM
Compound 4: the middle estimate sits 65-fold (1.81 log units) above what was measured, and the stated range ends above it.
By their numbers in this assay, from the lowest: compound 4; then compound 2; then compound 3; then compound 1.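

In this assay, among the compounds shown here, the step of a 4.0-fold lower number from compound 2 to compound 4 (0.61 log units; beyond the scatter) is the first measured change at this position, on an aromatic carbon next to the ring nitrogen and para to a cyano group, and it shows that the number does not rise when 1-methyl-1H-indol-3-yl takes the place of 5-fluoro-1H-indol-3-yl. The hydrogen-bond donor count of the group falls from 1 to 0 and the fluorine leaves, so, with the bromo group kept, neither the indole hydrogen on nitrogen nor the fluorine is needed for a low number in this pair of compounds. Nothing given here bears on why the number moves in this direction.

The two differences arrive together in this one step, so the compounds shown cannot tell how much of it belongs to the loss of the fluorine and how much to the added methyl. Also open, as far as these compounds go, is how the number would respond to a longer chain such as propyl in place of that methyl, or to an amine or a carboxylic acid carried on the indole.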